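The source may hold more compounds than are shown below. What is called first, only, known or untested is meant among the compounds shown, and "the series" means these compounds.

In an assay on membranes from Jurkat cells for displacement of a labelled ligand from Sigma intracellular receptor 2 (Homo sapiens), read by scintillation counting, with a stated time of 1 h (a lower number here means a stronger inhibitor, a higher number a weaker inhibitor), compound 2 `CC(C)n1nc(CN2CCCC2)nc1-c1ccc(C(C)(C)C)cc1` gives 1460 nM, the higher of the two numbers obtained so far. Compound 3 `Cn1nc(CN2CCCC2)nc1-c1cccc(C(C)(C)C)c1` gives 1000 nM in this assay, a value within the scatter of that of compound 2. Compound 1 `Cn1nc(CN2CCCC2)nc1-c1ccc2ccsc2c1` sits at a limit rather than a number, (the limit of > 1000 nM in this assay, at which 1 of the 3 values shown sits), reported as > 1000 nM. Compound 4 `Cn1nc(CN2CCCC2)nc1-c1ccc(C(C)(C)C)cc1` has not yet been measured; it differs from compound 2 by methyl in place of isopropyl on an aromatic nitrogen. For the measured compounds named here, no step between measured compounds matches this change, but compound 3 carries the same methyl and gives 1000 nM, so the step is expected to be small in this assay, in either direction or none beyond the scatter. Compound 4 is therefore estimated at 1200 nM, between 500 nM and 3000 nM, meaning an expected step of a 1.2-fold lower number from compound 2 to compound 4 (0.09 log units; within the scatter).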

Compound 4, inhibition constant: > 1000 nM
Compound 4 was reported as a limit; the forecaster's own chance of this, stated with the estimate: 35%; the middle value is on the limit's open side.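

In this assay, for the compounds shown here, compound 4 gives only a limit, > 1000 nM, so no step from compound 2 to compound 4 can be read. The compounds shown leave open whether methyl in place of isopropyl on the aromatic nitrogen changes the number at all: the limit of > 1000 nM in this assay, at which 2 of the 4 values shown sit.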